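Naphthyl for dimethylaminophenyl on the benzylidene arm

The compounds below may be only part of what the source reports. "The series", "measured", "known", "first", "only" and "open" are said of these compounds alone.

Compound 1 `Cc1ccc(/C=C2\S/C(=N\c3csc(-c4ccc(Cl)cc4)c3)NC2=O)cc1` gives 6400 nM in a functional assay on HT-29 cells (Homo sapiens) for cytotoxicity, read by MTT assay, with a stated time of 72 h; a higher number here means a weaker inhibitor, a lower number a stronger inhibitor.
Compound 2 `CN(C)c1ccc(/C=C2\S/C(=N\c3csc(-c4ccc(Cl)cc4)c3)NC2=O)cc1` gives 1500 nM in this assay.

Among the compounds with values here, compound 2 holds the lowest of the two numbers measured so far. Within the data shown here, its nearest neighbour is compound 1, and the only step recorded, a 4.3-fold lower number from compound 1 to compound 2 (0.63 log units; beyond the scatter), arises from dimethylamino in place of methyl on an aromatic carbon.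

Compound 3 `O=C1N/C(=N/c2csc(-c3ccc(Cl)cc3)c2)S/C1=C\c1ccc2ccccc2c1` has not been measured. It differs from compound 2 by naphthalen-2-yl in place of 4-(dimethylamino)phenyl on a double-bonded chain carbon bound to a double-bonded ring carbon. The new group carries no hydrogen-bond acceptor, and in that respect compound 3 resembles compound 1 more than compound 2. Among the measured compounds shown here, the measured step that bears on this change is the one from compound 1 to compound 2, where adding the dimethylamino group lowered the number by a modest amount beyond the scatter; removing that acceptor again, while adding a second aromatic ring, would be expected to give back some of that gain. The account therefore expects a step of a 3.3-fold higher number from compound 2 to compound 3 (0.52 log units; beyond the scatter) toward a higher number for compound 3. The estimate for compound 3 in this assay is 5000 nM, with a range from 1500 nM to 20000 nM.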

Compound 3, half-maximal inhibitory concentration: 3700 nM
For compound 3 the middle estimate is 1.4-fold (0.13 log units) above the measured one, and the stated range covers the measured number.
By their numbers in this assay, from the lowest: compound 2; then compounds 3 and 1 (each within the scatter of the next).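

In this assay, naphthalen-2-yl in place of 4-(dimethylamino)phenyl on a double-bonded chain carbon bound to a double-bonded ring carbon gives a 2.5-fold higher number from compound 2 to compound 3 (0.39 log units; beyond the scatter) and so does not retain the number of compound 2. The second comparison, a 1.7-fold lower number from compound 1 to compound 3 (0.24 log units; within the scatter) in the same assay, shows that the 2 six-membered aromatic rings of naphthalen-2-yl do not separate compound 3 from compound 1, which carries 4-methylphenyl. Among these three compounds, 4-(dimethylamino)phenyl is therefore the only group at this position whose steps to both others lie beyond the scatter, and nothing available here accounts for that difference.

The compounds shown leave open whether this separation belongs to dimethylamino itself or would also appear with another group at the same place, such as a 4-methoxyphenyl, a 4-(diethylamino)phenyl or a 4-(pyrrolidin-1-yl)phenyl. They also leave open whether a naphthalen-1-yl would behave like naphthalen-2-yl, and whether the same order would hold if the 4-chlorophenyl group elsewhere on the shared core were replaced by, for example, a 4-methoxyphenyl.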